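The source may report more compounds than this note shows. Statements on the series, on what has been measured and on what is new or still open speak of the compounds shown alone.

Compound 1 `CC1(C)CC(NC(=S)Nc2cccc([N+](=O)[O-])c2)c2cc(Br)ccc2O1`: 4000 nM
Compound 2 `CC1(C)CC(NC(=O)Nc2ccc(Cl)cc2)c2cc(F)ccc2O1`: 30000 nM
Compound 3 `CC1(C)CC(NC(=O)NCc2ccccc2)c2cc(Cl)ccc2O1`: 15000 nM

All three values come from a functional assay on T98G cells (Homo sapiens) for inhibition, read by MTT assay, with a stated time of 72 h; on this read-out lower numbers stand for stronger inhibition and higher numbers for weaker inhibition. Compound 1 has the lowest number of the three. Compound 3 at 15000 nM and compound 2 at 30000 nM both lie above it, beyond the scatter, so compound 1 is the most potent of this small set. These three compounds differ from one another in more than one place, so their values cannot be assigned to any single structural change.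

The next compound to be read is compound 4 `COc1cccc(NC(=S)NC2CC(C)(C)Oc3ccc(Br)cc32)c1`. It keeps the rest of compound 1 and carries methoxy in place of nitro on an aromatic carbon, meta to a large group. Going by the values given here, no measured pair shows this change, or any other single change, so the expectation here is loose. With compound 1 at 4000 nM already the lowest number in this assay, a move towards a higher number seems more likely than a further drop, probably of modest size. The expected change is a 2.0-fold higher number from compound 1 to compound 4 (0.30 log units; within the scatter). For compound 4 the estimated value is 8000 nM, with an expected range from 3000 nM to 25000 nM.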

Compound 4, half-maximal inhibitory concentration: 87000 nM
Compound 4: middle estimate off by 11-fold (1.04 log units), on the low side, outside the stated range (above it).
By their numbers in this assay, from the lowest: compound 1; then compounds 3 and 2 (each within the scatter of the next); then compound 4.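

Going by these compounds alone, with methoxy in place of nitro on an aromatic carbon, meta to a large group, this assay gives a 22-fold higher number from compound 1 to compound 4 (1.34 log units; beyond the scatter) and provides the first single-change comparison. The rest of compound 1 is held, so this step belongs to the exchange of nitro, with 3 heavy atoms and 2 hydrogen-bond acceptors, for methoxy, with 2 heavy atoms and 1 hydrogen-bond acceptor, and the read-out at this position clearly depends on the group it carries. No measured property of either group is available to account for the size of the step.

Still open, from the compounds shown here alone, is whether the step reflects the loss of nitro or the arrival of methoxy; a nitrile, an amine or a plain hydrogen on this carbon would help separate those two readings. Going by these compounds, it is also open whether the same exchange gives a step of similar size on another aromatic carbon of this ring, or in a compound with chlorine or fluorine in place of the bromine of compound 1.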